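This account rests on a few compounds, and the source may have more. Where it says the series, first, only, none or still open, it means among the compounds named here.

Compound 2 `Nc1ncnc(Oc2ccc(NC(=O)C3(C(=O)Nc4ccc(F)cc4)CC3)cc2F)c1/C=N/OCc1ccccc1` gives 4.45 in a physicochemical assay for lipophilicity, using the shake flask method (on this read-out higher numbers stand for higher lipophilicity and lower numbers for lower lipophilicity), the higher of the two numbers recorded, while compound 1 `CCO/N=C/c1c(N)ncnc1Oc1ccc(NC(=O)C2(C(=O)Nc3ccc(F)cc3)CC2)cc1F` gives 3.41 in this assay. Among the measured compounds shown here, the one step measured between them, a number 1.04 log units higher from compound 1 to compound 2 (beyond the scatter), is the only guide to the change at this position. Compound 3 `Nc1ncnc(Oc2ccc(NC(=O)C3(C(=O)Nc4ccc(F)cc4)CC3)cc2F)c1/C=N/OCC(=O)N1CCOCC1` is not yet measured; it differs from compound 2 by (morpholin-4-yl)carbonyl in place of phenyl on a saturated chain carbon bound to an oxygen. The measured step shows how much of the number in this assay the phenyl carries, and compound 3 removes that phenyl again while the group that enters brings two hydrogen-bond acceptors and no aromatic ring. The step is therefore expected to go downward and to be larger than the one already seen, since compound 3 does not return to the methyl of compound 1. Compound 3 is estimated at 2.1, with a range from 1.5 to 2.8, so that the expected step is a number 2.35 log units lower from compound 2 to compound 3 (beyond the scatter).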

Compound 3, partition coefficient: 2.1
For compound 3 middle estimate and measured number coincide at the digits printed; low and high end bracket the measured number.
By their numbers in this assay, from the lowest: compound 3; then compound 1; then compound 2.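

The earlier pair showed this position only moving upward, with phenyl in place of methyl. With (morpholin-4-yl)carbonyl entering, this assay gives a number 2.35 log units lower from compound 2 to compound 3 (beyond the scatter), so the same position can also carry the number well down. The new group does not merely cancel the gain from phenyl: it gives a number 1.31 log units lower from compound 1 to compound 3 (beyond the scatter), which places compound 3 beyond the methyl-bearing compound on the low side. Nothing available here explains the size of these steps.

The compounds shown do not separate what the carbonyl contributes from what the morpholine ring contributes, since the two enter together. They also leave open where a carboxylic acid, a dimethylamide or a longer chain ending in an amine would fall in this assay.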